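Swapping Chloro for Nitro on a Weakly Cytotoxic Scaffold

A few compounds are considered here, and "the series" means these few. Any claim that something is new, unique, unknown or untested is made for them only; others in the source may bear on it.

Compound 1 `O=C(CN1CCN(c2ccc(Cl)cc2)CC1)N1CCN(c2nnc(-c3ccccc3)c(-c3ccccc3)n2)CC1` joins a 4-chlorophenyl group through two piperazine rings and an amide to a triazine bearing two phenyl rings. In a functional assay on MCF7 cells (Homo sapiens) for cytotoxicity, read by MTT assay, with a stated time of 24 h (on this read-out lower numbers stand for stronger inhibition and higher numbers for weaker inhibition), compound 1 gives 56300 nM. Compound 2 `O=C(CN1CCN(c2ccc([N+](=O)[O-])cc2)CC1)N1CCN(c2nnc(-c3ccccc3)c(-c3ccccc3)n2)CC1` differs from compound 1 only by nitro in place of chloro on an aromatic carbon. In this assay compound 2 gives only a limit of the assay, > 886000 nM. The step of an at least 15-fold higher number from compound 1 to compound 2 (1.19 log units; beyond the scatter) is therefore bounded by the limit of > 886000 nM in this assay, at which 1 of the 3 values shown sits, and its full size cannot be read.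

Compound 3 `Cc1ccc(-c2nnc(N3CCN(C(=O)CN4CCN(c5ccc(Cl)cc5)CC4)CC3)nc2-c2ccc(C)cc2)cc1` has a different core; the difference between the core of compound 1 and the core of compound 3 is not broken down here. In this assay compound 3 gives 660000 nM, the higher of the two numbers, so the values of compound 1 and compound 3 show compound 3 inhibiting more weakly.

Compound 4 `Cc1ccc(-c2nnc(N3CCN(C(=O)CN4CCN(c5ccc([N+](=O)[O-])cc5)CC4)CC3)nc2-c2ccc(C)cc2)cc1` has not yet been measured. It relates to compound 3 by nitro in place of chloro on an aromatic carbon, the same change that turned compound 1 into compound 2. Resting on the step of an at least 15-fold higher number from compound 1 to compound 2 (1.19 log units; beyond the scatter), compound 4 is expected to show a 4.5-fold higher number from compound 3 to compound 4 (0.66 log units; beyond the scatter). Compound 4 is estimated at 3000000 nM, with a likely range from 900000 nM to 10000000 nM. Compound 3 already sits close to the limit of > 886000 nM in this assay, at which 1 of the 3 values shown sits, so compound 4 will most likely be reported as a limit rather than a number.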

Compound 4, half-maximal inhibitory concentration: 845000 nM
For compound 4 the middle estimate is 3.6-fold (0.55 log units) above the measured one; the whole stated range lies above it.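

In this assay, nitro in place of chloro on the core of compound 3 gives a 1.3-fold higher number from compound 3 to compound 4 (0.11 log units; within the scatter), so on this core the swap from 4-chlorophenyl to 4-nitrophenyl leaves no change that can be told apart from the ordinary spread of repeated measurements. The same change therefore does not carry over from one core to the other with the same size, and a step read on the core of compound 1 would have been a poor guide to the step on the core of compound 3: the same change on two cores in this assay, an at least 15-fold higher number (1.19 log units; beyond the scatter) from compound 1 to compound 2 and a 1.3-fold higher number (0.11 log units; within the scatter) from compound 3 to compound 4, at least 12-fold (1.08 log units) apart, beyond the scatter of two such steps What this does not show is the full size of the first step, or the reason the two cores behave differently; the first step ends at a limit of the assay rather than at a number: the limit of > 886000 nM in this assay, at which 1 of the 4 values shown sits.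

On these data alone, only chloro and nitro appear at this place on the ring, so it remains open whether other groups there, such as an amine or a carboxylic acid, would also give steps that depend on the core. As far as these compounds go, with just two pairs of compounds, it also remains open whether the gap between the steps would hold on any further core.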